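A few compounds are considered here, and "the series" means these few. Any claim that something is new, unique, unknown or untested is made for them only; others in the source may bear on it.

Series notes. Within the data shown here, in an assay on CHO cells for displacement of a labelled ligand from adenosine receptor A3 (Homo sapiens), read by scintillation counting, with a stated time of 3 h (on this read-out lower numbers stand for stronger inhibition and higher numbers for weaker inhibition), compound 3 `Cn1cc2c(Cl)nc(NC(=O)c3ccc(F)cc3)nc2n1` gives 31900 nM, the highest of the three numbers measured so far. Compound 2 `Cn1cc2c(Cl)nc(NC(=O)c3ccccc3)nc2n1` gives 23600 nM, and the step of a 1.4-fold higher number from compound 2 to compound 3 (0.13 log units; within the scatter) shows that exchanging hydrogen for fluoro there barely moves the read-out. Compound 1 `Cc1ccc(C(=O)Nc2nc(Cl)c3cn(CC(C)(C)C)nc3n2)cc1` gives 5000 nM, the lowest number of the three.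

Compound 4 `CC(C)(C)Cn1cc2c(Cl)nc(NC(=O)c3ccc(F)cc3)nc2n1` is compound 3 with tert-butyl in place of hydrogen on a saturated chain carbon bound to an aromatic nitrogen. Among the measured compounds shown here, no measured pair differs only in this place, so the step has no direct precedent. The closest comparison is compound 1, which differs from compound 3 in two places: the same methyl-to-neopentyl exchange, plus a second change in the amide part. For the measured compounds named here, the values of compound 1 and compound 3 stand well apart, beyond the scatter, whereas the only single-place step available, a 1.4-fold higher number from compound 2 to compound 3 (0.13 log units; within the scatter), was within the scatter. Going by the values given here, because compound 1 gives 5000 nM while the only single-place step a 1.4-fold higher number from compound 2 to compound 3 (0.13 log units; within the scatter) stays within the scatter, most of the gap between compound 1 and compound 3 is provisionally attributed to the neopentyl exchange. Compound 4 is therefore expected to move toward the number of compound 1. The estimated step is a 5.3-fold lower number from compound 3 to compound 4 (0.73 log units; beyond the scatter). The expected value for compound 4 is 6000 nM, with a range from 2000 nM to 18000 nM, the range kept wide since the inference rests on a two-place comparison.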

Compound 4, inhibition constant: 5900 nM
Compound 4: the middle estimate sits 1.0-fold (0.01 log units) above what was measured; the measured number falls inside the stated range.
By their numbers in this assay, from the lowest: compounds 1 and 4 (each within the scatter of the next); then compounds 2 and 3 (each within the scatter of the next).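

In this assay, among these compounds, the change from methyl to neopentyl, read on its own for the first time, gives a 5.4-fold lower number from compound 3 to compound 4 (0.73 log units; beyond the scatter), so this saturated chain carbon bound to an aromatic nitrogen is a place where the read-out responds to a change. The other new step, a 1.2-fold higher number from compound 1 to compound 4 (0.07 log units; within the scatter), stays within the scatter with neopentyl in place, as does a 1.4-fold higher number from compound 2 to compound 3 (0.13 log units; within the scatter) with methyl in place; across these four compounds, the exchanges on the aromatic carbon therefore leave the number within the scatter, and only the exchange on the nitrogen substituent goes beyond it. The data shown give no information on the origin of the shift seen with neopentyl.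

On these data alone, with only methyl and neopentyl at this place, it remains open whether the number follows chain length or branching, which an ethyl group, a straight butyl chain or a cyclohexylmethyl group could separate. Also open, as far as these compounds go, is how a chain ending in an amine or a carboxylic acid would read at this place, and whether an amine could take the place of the chloro on the shared core.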